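The source may hold more compounds than are shown below. What is called first, only, known or untested is meant among the compounds shown, and "the series" means these compounds.

Compound 1 `Cn1c(C(F)(F)F)ccc(NCc2cc3cc(Cl)ccc3[nH]c2=O)c1=O`: 85%
Compound 2 `N#Cc1ccc(NCc2cc3cc(Cl)ccc3[nH]c2=O)c(=O)[nH]1`: 100%
Compound 3 `CCn1cccc(NCc2cc3cc(Cl)ccc3[nH]c2=O)c1=O`: 72%

All three compounds share the same core, and all three were tested in an ADME assay on microsomes from liver (Homo sapiens) for metabolic stability, with a stated time of 30 min; on this read-out higher numbers stand for a more stable compound and lower numbers for a less stable compound. Compound 2 gives 100%, the highest of the three numbers. The nearest is compound 1, which gives 85%, a value that lies below compound 2 by more than the usual scatter. Furthest away is compound 3, which gives 72%, again lower than compound 2 by more than the scatter. For the measured compounds named here, with only three compounds, and no two of them differing in just one place, the numbers describe these three molecules alone and no broader pattern.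

Compound 4 `Cn1c(C#N)ccc(NCc2cc3cc(Cl)ccc3[nH]c2=O)c1=O` has not yet been measured. It differs from compound 2 in a single place: methyl in place of hydrogen on an aromatic nitrogen. Compound 2 already sits at the top of the read-out, so the step in this assay can hardly go upward. Compounds 1 and 3, which carry a methyl or ethyl on the same aromatic nitrogen, both sit below compound 2, so a moderate downward step is expected. Compound 4 is therefore expected to give about 85%, within the range 65% to 100%, an estimated step of a number 15 percentage points lower from compound 2 to compound 4 (beyond the scatter) in this assay.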

Compound 4, percent of the compound remaining in the Homo sapiens assay: 99%
Compound 4: middle estimate off by 14 percentage points, on the low side, and the stated range covers the measured number.
By their numbers in the Homo sapiens assay, from the lowest: compound 3; then compound 1; then compounds 4 and 2 (each within the scatter of the next).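

On the aromatic nitrogen ortho to a cyano group, methyl in place of hydrogen gives no readable change in the Homo sapiens assay, with a number 1 percentage points lower from compound 2 to compound 4 (within the scatter), so at this position the read-out stays at the top of its range with either group. Cyano in place of trifluoromethyl on an aromatic carbon, with the methyl kept on the nitrogen, gives in the Homo sapiens assay a number 14 percentage points higher from compound 1 to compound 4 (beyond the scatter), which places the only difference beyond the scatter among these single changes at that carbon rather than on the nitrogen. The methyl does show up elsewhere: in a physicochemical assay for solubility (on this read-out lower numbers stand for lower solubility and higher numbers for higher solubility), compound 2 gives 2210 nM and compound 4 gives 295 nM, so the methyl on the nitrogen goes with a clear drop in solubility: the measured solubility of compound 2, 2210 nM, and of compound 4, 295 nM, a 7.5-fold lower number (0.87 log units; beyond the scatter)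

The compounds shown leave open whether a longer chain on the nitrogen, such as propyl, or a hydroxyethyl chain would keep the number in the stability read-out while giving back some of the solubility. They also leave open how a carboxylic acid or an amine in place of the cyano group would behave in either read-out.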